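This account rests on a few compounds, and the source may have more. Where it says the series, first, only, none or still open, it means among the compounds named here.

Three compounds of the series have been run in an ADME assay on HFF cells (Homo sapiens) for cytotoxicity, read by MTT assay, with a stated time of 72 h; on this read-out higher numbers stand for weaker inhibition and lower numbers for stronger inhibition. Compound 1 `O=C1O/C(=C\Cn2cc(-c3ccc(Br)cc3)nn2)C(OCc2ccccc2)=C1OCc1ccccc1` returns only the assay limit, > 100000 nM. Compound 3 `COc1ccccc1-c1cn(C/C=C2\OC(=O)C(OCc3ccccc3)=C2OCc2ccccc2)nn1` likewise returns only the limit, > 100000 nM. The step that the two limits leave unreadable from compound 1 to compound 3 therefore has no readable size. Going by the values given here, compound 2 `CCCCc1cn(C[C@H](O)[C@H]2OC(=O)C(OCc3ccccc3)=C2OCc2ccccc2)nn1` is the one compound with a number, giving 26300 nM in this assay. The values of compound 1 and compound 3 are limits, and the limit of > 100000 nM in this assay, at which 2 of the 3 values shown sit, marks where both sit. Compound 4 `O=C1O[C@H]([C@@H](O)Cn2cc(CNS(=O)(=O)c3ccc(Cl)cc3)nn2)C(OCc2ccccc2)=C1OCc1ccccc1` is to be measured in this assay. Relative to compound 2 the change is ((4-chlorophenyl)sulfonyl)amino in place of propyl on a saturated chain carbon bound to an aromatic carbon. Among the compounds with values here, no measured step touches this change: the only step measured swaps a group on an aromatic carbon and is unreadable from its two limits. The expectation therefore rests on compound 2 alone, with the step estimated as a 1.3-fold higher number from compound 2 to compound 4 (0.12 log units; within the scatter), that is no shift beyond the scatter, and a fair chance that only a limit comes back. Compound 4 is expected to give about 35000 nM, with a range from 10000 nM to 120000 nM.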

Compound 4, half-maximal inhibitory concentration: 20 nM
Compound 4: middle estimate off by 1800-fold (3.24 log units), on the high side, and the stated range ends above it.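

In this assay, ((4-chlorophenyl)sulfonyl)amino in place of propyl on a saturated chain carbon bound to an aromatic carbon gives a 1300-fold lower number from compound 2 to compound 4 (3.12 log units; beyond the scatter), so this place has a large bearing on the read-out. The series previously held a single number and one unreadable step on an aromatic carbon, whereas compound 2 and compound 4 now give a readable pair that differs in this one place. Compound 1 and compound 3 remain limits and add nothing to this comparison: the limit of > 100000 nM in this assay, at which 2 of the 4 values shown sit.

The change brings in the sulfonyl, the amino hydrogen and the 4-chlorophenyl ring together, and the compounds shown do not separate their shares in the step. On these data alone, how a carboxamide in place of the sulfonamide, or an unsubstituted phenyl ring in place of 4-chlorophenyl, would read in this assay remains open.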